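Swapping one halogen on the amide-side ring

This account rests on a few compounds, and the source may have more. Where it says the series, first, only, none or still open, it means among the compounds named here.

Compound 1: `O=C(CSc1nc(Nc2ccccc2)c2ccccc2n1)Nc1ccc([N+](=O)[O-])cc1` — > 50000 nM
Compound 2: `O=C(CSc1nc(Nc2ccccc2)c2ccccc2n1)Nc1ccc(Cl)c(Cl)c1` — 37900 nM

Two compounds share the same core and differ only in the ring attached to the amide nitrogen. In a functional assay on MGC-803 cells (Homo sapiens) for inhibition, read by MTT assay, with a stated time of 72 h (a higher number here means a weaker inhibitor, a lower number a stronger inhibitor), compound 1 gives only a limit, > 50000 nM, not a number. In this assay compound 2 gives 37900 nM, the only number shown, so compound 2 is simply the single measured point; the step of an at least 1.3-fold lower number from compound 1 to compound 2 (0.12 log units; that floor lies within the scatter) cannot be sized beyond its floor, since the limit of > 50000 nM in this assay, at which 1 of the 2 values shown sits, cuts it off.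

Compound 3, `O=C(CSc1nc(Nc2ccccc2)c2ccccc2n1)Nc1ccc(F)c(Cl)c1`, differs from compound 2 by fluoro in place of chloro on an aromatic carbon. No measured step trades one halogen for another: the only shown step changes the whole substitution pattern on that ring and still lands within the scatter. A swap of a single chloro for fluoro is a smaller change than that, so no step beyond the scatter is expected in this assay in either direction.

Compound 3 is therefore expected to give 40000 nM in this assay, within 15000 nM to 110000 nM, an estimated step of a 1.1-fold higher number from compound 2 to compound 3 (0.02 log units; within the scatter).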

Compound 3, half-maximal inhibitory concentration: 20900 nM
Compound 3: the middle estimate sits 1.9-fold (0.28 log units) above what was measured, and the stated range covers the measured number.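

In this assay, fluoro in place of chloro on this aromatic carbon, ortho to a chloro group and para to a large group, gives a 1.8-fold lower number from compound 2 to compound 3 (0.26 log units; within the scatter), so this swap of one halogen for another produces no change that can be told apart from repeat-measurement noise. Set against the nitro-bearing ring, the 3-chloro-4-fluorophenyl group gives an at least 2.3-fold lower number from compound 1 to compound 3 (0.37 log units; beyond the scatter), the first step in this set to pass beyond the scatter, whereas the 3,4-dichlorophenyl group gave an at least 1.3-fold lower number from compound 1 to compound 2 (0.12 log units; that floor lies within the scatter). The value of compound 1 is a limit and not a number, so the true size of both steps stays hidden and only their floors can be read: the limit of > 50000 nM in this assay, at which 1 of the 3 values shown sits.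

The compounds shown cannot tell whether the chloro group kept in compound 3 matters, or how a bromo, a methoxy or an amine would read on the aromatic carbon para to the large group. The shared core is the same in all three compounds, so they also leave open what a carboxylic acid or a longer chain elsewhere on the molecule would do in this assay.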